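The source may report more compounds than this note shows. Statements on the series, on what has been measured and on what is new or still open speak of the compounds shown alone.

In a functional assay on PC-12 cells (Rattus norvegicus) for cytotoxicity, read by MTT assay, with stated times of 3 h and 2 h, tested at 5 uM (on this read-out lower numbers stand for a weaker effect and higher numbers for a stronger effect at the one concentration tested), two compounds have been measured:

Compound 1 `Cc1cc(=O)oc2cc(OCCCn3cc(CNC(=O)CCCCC4CCSS4)nn3)ccc12` gives 64.6%

Compound 2 `CC(=O)c1cc2ccc(OCCCn3cc(CNC(=O)CCCCC4CCSS4)nn3)cc2oc1=O` gives 37.5%

Compound 2 is the lower of the two numbers, and its gap to compound 1 is wider than the usual scatter of repeated measurements. What the two structures share is a long tail carrying a cyclic disulfide and an amide; they differ only in the small group on the shared core.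

Compound 3 `O=C(CCCCC1CCSS1)NCc1cn(CCCOc2ccc3cc(C(=O)O)c(=O)oc3c2)nn1` keeps everything of compound 2 but changes that carbonyl group: hydroxy in place of methyl on a carbonyl carbon. Among the compounds with values here, nothing among the measured pairs shows what such a change does here, so no step can be read off. The expected step of a number 4.5 percentage points lower from compound 2 to compound 3 (within the scatter) is small, at most a slight decrease, and may fall within the scatter. Compound 3 is therefore estimated at 33%, with a range from 15% to 55%.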

Compound 3, a percentage reported as activity, at one concentration (the size of the read-out at that concentration, not a potency): 57%
Compound 3: middle estimate off by 24 percentage points, on the low side; measured number outside the range, above it.
By their numbers in this assay, from the lowest: compound 2; then compounds 3 and 1 (each within the scatter of the next).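

In this assay, hydroxy in place of methyl on a carbonyl carbon gives a number 19.5 percentage points higher from compound 2 to compound 3 (beyond the scatter). Within the data shown here, this is the first step that can be read at this place, and it shows that the read-out at the one concentration tested responds to the group on this carbonyl carbon: turning acetyl into carboxy changes only one heavy atom, yet the step lies beyond the usual scatter. Nothing available explains why the number moves in this direction.

As far as these compounds go, whether a primary amide or a methyl ester on the same carbonyl carbon would also raise the number remains open. From the compounds shown here alone, it is also open whether the acetyl to carboxy change would give a similar step if a longer chain replaced the one that carries the cyclic disulfide.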